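Trading a dimethylcarbamoyl for an isopropyl

The source may hold more compounds than are shown below. What is called first, only, known or untested is meant among the compounds shown, and "the series" means these compounds.

Compound 1 `COC(=O)Cn1nnc(Cc2ccc(-c3ccccc3)cc2)n1` and compound 2 `CN(C)C(=O)Cn1nnc(CNC(=O)c2ccc(-c3ccccc3)cc2)n1` have both been tested in an assay on isolated protein (COS cells) for inhibition of diacylglycerol lipase-alpha (Homo sapiens); a lower number here means a stronger inhibitor, a higher number a weaker inhibitor. For compound 1 the result is a limit of the assay and not a number, > 10000 nM. For compound 2 the result is likewise a limit of the assay, > 10000 nM. Within the data shown here, compound 2 therefore stands at the limit of > 10000 nM in this assay, at which 2 of the 2 values shown sit, and no measured step between two real numbers exists in this set. Compound 3 `CC(C)Cn1nnc(CNC(=O)c2ccc(-c3ccccc3)cc2)n1` has not yet been measured in this assay. It differs from compound 2 by isopropyl in place of dimethylcarbamoyl on a saturated chain carbon bound to an aromatic nitrogen. Among the measured compounds shown here, no measured step is available from which a direction could be read; for the step from compound 2 to compound 3 one expects no change beyond the scatter, namely a step that the limit leaves unreadable from compound 2 to compound 3. In this assay compound 3 is accordingly estimated at 15000 nM, with a range from 3000 nM to 100000 nM.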

Compound 3, half-maximal inhibitory concentration: > 10000 nM
Compound 3 ended at the assay's limit; the forecaster's own chance of this, stated with the estimate: 70%; the middle value lies beyond the limit too.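

Compound 2 and compound 3 both stand at a limit of this assay and not at a number, so no step between them can be read: the limit of > 10000 nM in this assay, at which 3 of the 3 values shown sit.

The compounds shown leave open whether trading dimethylcarbamoyl for isopropyl changes inhibition at all, since none of them gives a measured number.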